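The compounds below may be only part of what the source reports. "The series", "measured", "known", "first", "only" and "open" are said of these compounds alone.

Measured compounds in a functional assay on SK-MEL-28 cells (Homo sapiens) for cytotoxicity, read by MTT assay; a lower number here means a stronger inhibitor, a higher number a weaker inhibitor:

Compound 1 `Cc1ccc(S(=O)(=O)NCCNc2nccc(-c3c(-c4cccc(F)c4)nc4sccn34)n2)cc1` gives > 20000 nM, a limit of this assay.
Compound 2 `O=C(NCCNc1nccc(-c2c(-c3cccc(F)c3)nc3sccn23)n1)c1ccc(Cl)cc1` gives 8160 nM.
Compound 3 `O=C(NCCCNc1nccc(-c2c(-c3cccc(F)c3)nc3sccn23)n1)c1ccc(Cl)cc1` gives > 20000 nM, a limit of this assay.

Compound 2 is the only one of the three with a number rather than a limit. From compound 2 the change (4-methylphenyl)sulfonyl in place of (4-chlorophenyl)carbonyl on an amine nitrogen gives an at least 2.4-fold higher number from compound 2 to compound 1 (0.38 log units; beyond the scatter); the step reads as at least that size because of the limit of > 20000 nM in this assay, at which 2 of the 3 values shown sit. The core of compound 3 differs from that of compound 2 by (((4-chlorophenyl)carbonyl)amino)methyl in place of ((4-chlorophenyl)carbonyl)amino on a saturated chain carbon, two bonds along the chain from a nitrogen on an aromatic ring, and this change gives an at least 2.4-fold higher number from compound 2 to compound 3 (0.38 log units; beyond the scatter). Between compound 1 and compound 3 the change is a step that the two limits leave unreadable from compound 1 to compound 3, both values sitting at the same limit.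

Compound 4 `Cc1ccc(S(=O)(=O)NCCCNc2nccc(-c3c(-c4cccc(F)c4)nc4sccn34)n2)cc1` is not yet measured. It differs from compound 3 by (4-methylphenyl)sulfonyl in place of (4-chlorophenyl)carbonyl on an amine nitrogen. This is the same change as from compound 2 to compound 1: the place lines are identical word for word, an amine nitrogen whose other neighbour is a saturated chain carbon. That earlier instance of the change weakened inhibition, an at least 2.4-fold higher number from compound 2 to compound 1 (0.38 log units; beyond the scatter), and compound 3 already sits at the limit of this assay.

Compound 4 is therefore expected to give a step that the limit leaves unreadable from compound 3 to compound 4 in this assay, which would place it at 40000 nM, within a range from 15000 nM to 150000 nM, most likely reported only as a limit.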

Compound 4, half-maximal inhibitory concentration: 9500 nM
Estimate against measurement, compound 4: 4.2-fold (0.62 log units) above; measured number outside the range, below it.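

In this assay, placing (4-methylphenyl)sulfonyl in place of (4-chlorophenyl)carbonyl on the amine nitrogen does not carry from the core of compound 2 to the core of compound 3, and the direction of the step reverses: the same change on two cores in this assay, an at least 2.4-fold higher number (0.38 log units; beyond the scatter) from compound 2 to compound 1 and an at least 2.1-fold lower number (0.32 log units; beyond the scatter) from compound 3 to compound 4, at least 5.1-fold (0.71 log units) apart, beyond the scatter of two such steps

On the core of compound 3 the change gives an at least 2.1-fold lower number from compound 3 to compound 4 (0.32 log units; beyond the scatter), which leaves the sulfonyl compound with the longer chain level with the carbonyl compound with the shorter one, at a 1.2-fold higher number from compound 2 to compound 4 (0.07 log units; within the scatter), while the (((4-methylphenyl)sulfonyl)amino)methyl side chain gives an at least 2.1-fold lower number from compound 1 to compound 4 (0.32 log units; beyond the scatter), opposite in direction to an at least 2.4-fold higher number from compound 2 to compound 3 (0.38 log units; beyond the scatter). This shows that in these four compounds the effect of the change depends on the chain that carries it, but it gives neither the true size of either step nor a reason for the reversal, and it rests on a single pair of cores, with the sizes left as bounds: the limit of > 20000 nM in this assay, at which 2 of the 4 values shown sit.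

The change swaps the carbonyl for a sulfonyl and the chlorine for a methyl at once, so the compounds shown leave open which part goes with the reversal; a (4-methylphenyl)carbonyl or a (4-chlorophenyl)sulfonyl group on either chain would separate the two. From the compounds shown here alone, whether the reversal persists on a still longer chain also remains open.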